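Hydroxy to acetoxy on compound 2

The source may hold more compounds than are shown below. What is called first, only, known or untested is meant among the compounds shown, and "the series" means these compounds.

compound 1 `CC1=CC[C@H]2[C@@H]1CC=C(C)[C@@H](CC[C@H]1[C@]3(C)CC[C@H](O)C(C)(C)O[C@H]3CC[C@@]1(C)O)C2(C)C`: > 50000 nM
compound 2 `CC(=O)O[C@H]1CC[C@]2(C)[C@H](CC[C@@](C)(O)[C@H]2CC[C@@H]2C(C)=CC[C@H]3[C@H](CC[C@]3(C)O)C2(C)C)OC1(C)C`: 47900 nM

In a functional assay on MCF7 cells (Homo sapiens) for antiproliferative activity, read by MTT assay, with a stated time of 72 h (on this read-out lower numbers stand for stronger inhibition and higher numbers for weaker inhibition), compound 1 gives > 50000 nM, a limit and not a number. Going by the values given here, compound 2, at 47900 nM, holds the only true number. Compound 3 `CC(=O)O[C@H]1CC[C@]2(C)[C@H](CC[C@@](C)(O)[C@H]2CC[C@@H]2C(C)=CC[C@H]3[C@H](CC[C@]3(C)OC(C)=O)C2(C)C)OC1(C)C` differs from compound 2 by acetyl in place of hydrogen on an oxygen on a saturated carbon, hydroxy to acetoxy. Among the compounds with values here, no measured single-place step exists to calibrate this change. The expected 1.2-fold lower number from compound 2 to compound 3 (0.08 log units; within the scatter) stays within the scatter, with no clear direction in this assay. For compound 3 the estimated value is 40000 nM, with an expected range of 15000 nM to 90000 nM.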

Compound 3, half-maximal inhibitory concentration: 39200 nM
The estimate for compound 3 lay 1.0-fold (0.01 log units) above the measured number; low and high end bracket the measured number.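

In this assay, going by these compounds alone, acetyl in place of hydrogen on an oxygen on a saturated carbon gives a 1.2-fold lower number from compound 2 to compound 3 (0.09 log units; within the scatter), the first step that can be read. At this position, hydroxy to acetoxy therefore brings no clear shift in the antiproliferative read-out, and the acetyl is tolerated without loss of a true number. The series still sits close to the edge of what this read-out reports: the limit of > 50000 nM in this assay, at which 1 of the 3 values shown sits.

On these data alone, whether an amine or a carboxylic acid on this saturated carbon, or a longer chain in place of the acetyl, would move the number beyond the scatter stays open.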